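A Pyridyl for a Furyl on a Shared Core

This account rests on a few compounds, and the source may have more. Where it says the series, first, only, none or still open, it means among the compounds named here.

Compound 1, `O=C1Nc2ccc(Br)cc2C1=Cc1ccco1`, is the only one of the three measured compounds that returns a number in an ADME assay on A549 cells (Homo sapiens) for cytotoxicity, read by MTT assay, with a stated time of 72 h; on this read-out higher numbers stand for weaker inhibition and lower numbers for stronger inhibition: in this assay compound 1 gives 449000 nM, a weak inhibition. Compound 2, `COC(=O)Nc1ccc2c(c1)C(=Cc1ccc([N+](=O)[O-])cc1)C(=O)N2`, reaches only a limit in this assay, reported as > 100000 nM. Compound 3, `Cc1ccc(C(=O)CC2(O)C(=O)Nc3ccc(Nc4ccco4)cc32)cc1`, likewise reaches only a limit in this assay, reported as > 100000 nM. Among the compounds with values here, two of the three values shown thus sit at the limit of > 100000 nM in this assay, at which 2 of the 3 values shown sit, and compound 1 stands alone as the sole measured number, so there is no ordering among the three beyond that. Within the data shown here, no two measured compounds differ in only one place, so no measured step is available to calibrate the change that follows.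

Compound 4, `O=C1Nc2ccc(Br)cc2C1=Cc1cccnc1`, differs from compound 1 by pyridin-3-yl in place of furan-2-yl on a double-bonded chain carbon bound to a double-bonded ring carbon. The shared core, including its bromine, is untouched. Among the measured compounds shown here, with no measured step to lean on, the step from compound 1 to compound 4 is expected to be small, a 1.1-fold lower number from compound 1 to compound 4 (0.05 log units; within the scatter), falling within the usual scatter rather than shifting in either direction. Compound 4 is therefore expected to give about 400000 nM in this assay, with a range from 150000 nM to 1200000 nM, and a real chance that only a limit is reported.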

Compound 4, half-maximal inhibitory concentration: 31400 nM
Compound 4: the middle estimate sits 13-fold (1.11 log units) above what was measured; the measured number lies below the stated range.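

In this assay, within the data shown here, pyridin-3-yl in place of furan-2-yl on a double-bonded chain carbon bound to a double-bonded ring carbon gives a 14-fold lower number from compound 1 to compound 4 (1.16 log units; beyond the scatter), the first one-place step in this set, and it shows that this position alone can move the read-out well beyond the scatter while the bromine of the shared core stays as it is. The change is also not one of the simple counts: both groups are single aromatic rings with a single hetero atom, with the same counts of hydrogen-bond donors and acceptors and no net charge, and they differ in ring size and in oxygen against nitrogen. Nothing measured in the material shown accounts for the size of this step.

The compounds shown leave open whether the stronger inhibition follows the ring nitrogen or the six-membered ring, a question that phenyl or pyridin-2-yl at the same place would address. They also leave open whether the step holds when an amine or a methoxy group stands in place of the bromine on the shared core.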